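A few compounds are considered here, and "the series" means these few. Any claim that something is new, unique, unknown or untested is made for them only; others in the source may bear on it.

For the measured compounds named here, in a functional assay on MDA-MB-468 cells (Homo sapiens) for inhibition (a higher number here means a weaker inhibitor of growth, a lower number a stronger inhibitor of growth), compound 1 `NC(=O)c1cc(Cl)ccc1NC(=O)COc1ccccc1` gives 1740 nM and compound 2 `NC(=O)c1cc(I)ccc1NC(=O)COc1ccccc1` gives 351 nM, the lower of the two numbers so far. Compound 3 `COc1ccc(NC(=O)COc2ccccc2)c(C(N)=O)c1` has not yet been measured. It differs from compound 2 by methoxy in place of iodo on an aromatic carbon, meta to a carbamoyl group and para to a large group. Going by the values given here, only one measured step bears on this change. Iodo in place of chloro gave a 5.0-fold lower number from compound 1 to compound 2 (0.70 log units; beyond the scatter), which shows that the number responds to the group at this place. Among the compounds with values here, no measured compound carries methoxy, however, so the size of the next step remains uncertain. Since compound 2 at 351 nM holds the lowest number, a move upward of similar size is expected, an estimated 4.0-fold higher number from compound 2 to compound 3 (0.60 log units; beyond the scatter). For compound 3 the expected value is 1400 nM, with an estimated range of 450 nM to 4500 nM.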

Compound 3, concentration for 50% growth inhibition: 345 nM
Compound 3: middle estimate off by 4.1-fold (0.61 log units), on the high side; the whole stated range lies above it.
By their numbers in this assay, from the lowest: compounds 3 and 2 (each within the scatter of the next); then compound 1.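

In this assay, methoxy in place of iodo gives a 1.0-fold lower number from compound 2 to compound 3 (0.01 log units; within the scatter) even though the groups differ: methoxy enters with 2 heavy atoms and 1 hydrogen-bond acceptor, while iodo leaves with 1 heavy atom and 0 hydrogen-bond acceptors. Methoxy in place of chloro gives a 5.0-fold lower number from compound 1 to compound 3 (0.70 log units; beyond the scatter) and so matches the step seen with iodo, which shows that the lower number at this position is not peculiar to iodo and that, among these three groups, only chloro stands apart. Nothing measured on these compounds accounts for this pattern.

Going by these compounds, it remains open whether an amine, a carboxylic acid or a longer alkoxy chain on this aromatic carbon would keep the number near those of compound 2 and compound 3. The same holds for a plain hydrogen there.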